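Pyrrolidinyl for dimethylamino: cytotoxicity outlook on compound 4

The source may report more compounds than this note shows. Statements on the series, on what has been measured and on what is new or still open speak of the compounds shown alone.

The series shares one core. Compound 1 `COc1cccc(Nc2nc(C)cc(N(C)C)n2)c1` is measured in an ADME assay on Vero cells (Chlorocebus sabaeus) for cytotoxicity (on this read-out higher numbers stand for an effect only at larger amounts of compound and lower numbers for an effect already at smaller amounts), only as a limit of the assay, > 50100 nM. Compound 3 `Cc1cc(N(C)C)nc(N[C@H](C)c2ccccc2)n1` likewise reaches only a limit, > 50100 nM. Among the compounds with values here, compound 2 `COc1cc(Nc2nc(C)cc(N(C)C)n2)ccc1F` is the one member with an actual number: in this assay compound 2 gives 31600 nM, so compound 2 stands as the single defined value, while the limit of > 50100 nM in this assay, at which 2 of the 3 values shown sit, holds the other two. Within the data shown here, the one measured step, an at least 1.5-fold lower number from compound 1 to compound 2 (0.20 log units; that floor lies within the scatter), concerns a fluoro for hydrogen swap and is small.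

Compound 4 `COc1cc(Nc2nc(C)cc(N3CCCC3)n2)ccc1F` differs from compound 2 by pyrrolidin-1-yl in place of dimethylamino on an aromatic carbon. Among the measured compounds shown here, no measured step touches the amino substituent on the core, so nothing here sizes this change directly; the only measured step was within the scatter floor, and the same is expected for compound 4. The expected step from compound 2 to compound 4 is a 1.1-fold lower number from compound 2 to compound 4 (0.02 log units; within the scatter). Compound 4 is therefore estimated at 30000 nM, with a range from 12000 nM to 50000 nM, the upper end close to where the assay reports only a limit.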

Compound 4, half-maximal effective concentration: 20000 nM
The estimate for compound 4 lay 1.5-fold (0.18 log units) above the measured number, and the stated range covers the measured number.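

The amino substituent on the shared core now has a measured step in this assay: a 1.6-fold lower number from compound 2 to compound 4 (0.20 log units; within the scatter), on going from dimethylamino to pyrrolidin-1-yl. At this position, closing the two carbon arms of the amine into a five-membered non-aromatic ring therefore gives no change that can be told from the scatter, and compound 4 still reads as a defined number rather than a limit. Compound 1 and compound 3 remain limits of the assay and not numbers: the limit of > 50100 nM in this assay, at which 2 of the 4 values shown sit.

From the compounds shown here alone, with only these two tertiary amino groups at this position, the reach of the change stays open: a piperidin-1-yl, a morpholin-4-yl, a primary amine or a longer chain could still behave differently. Also open, going by these compounds, is whether pyrrolidin-1-yl reads the same on the core of compound 1, without the fluoro.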